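Removing an Aromatic Fluorine in Two Related Series

The source may report more compounds than this note shows. Statements on the series, on what has been measured and on what is new or still open speak of the compounds shown alone.

Compound 1 `CN(Cc1ccccc1F)C(=O)CNC(=O)c1ccc(S(C)(=O)=O)c([N+](=O)[O-])c1` and compound 3 `CN(Cc1ccccc1)C(=O)CNC(=O)c1ccc(S(C)(=O)=O)c([N+](=O)[O-])c1` share one core and differ only in that compound 3 carries hydrogen in place of fluoro on an aromatic carbon. In an assay on isolated protein for inhibition of thyroid hormone receptor beta (Homo sapiens), read by fluorescence polarization (on this read-out lower numbers stand for stronger inhibition and higher numbers for weaker inhibition), compound 1 gives 24000 nM. In this assay compound 3 gives 39000 nM, so the step of a 1.6-fold higher number from compound 1 to compound 3 (0.21 log units; within the scatter) is small. Compound 2 `CN(CC(=O)N1CCN(c2ccc(F)cc2)CC1)C(=O)c1ccc(S(C)(=O)=O)c([N+](=O)[O-])c1` rests on a different core, and the difference between the two cores is not broken down here. In this assay compound 2 gives only a limit, > 60000 nM, which is the limit of > 60000 nM in this assay, at which 1 of the 3 values shown sits. Compound 4 `CN(CC(=O)N1CCN(c2ccccc2)CC1)C(=O)c1ccc(S(C)(=O)=O)c([N+](=O)[O-])c1` derives from compound 2 by hydrogen in place of fluoro on an aromatic carbon. For the measured compounds named here, this is the same kind of change as the one from compound 1 to compound 3, though the place differs: ortho to a large group in the first pair, para to a large group in the second. Because the step of a 1.6-fold higher number from compound 1 to compound 3 (0.21 log units; within the scatter) stayed within the scatter, only a small step is expected a step that the limit leaves unreadable from compound 2 to compound 4, starting from a value that is already a limit. Compound 4 is therefore estimated at 90000 nM, between 40000 nM and 250000 nM, and will most likely again be reported only as a limit.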

Compound 4, half-maximal inhibitory concentration: > 60000 nM
Compound 4: a limit, no number (the forecaster's own chance of this, stated with the estimate: 75%); the middle value lies beyond the limit too.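

In this assay, compound 2 and compound 4 each give only a limit and not a number, so no step can be read between them: the limit of > 60000 nM in this assay, at which 2 of the 4 values shown sit.

The compounds shown leave open whether going from 4-fluorophenyl to phenyl on this core changes the read-out at all.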